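Pyrazolyl enone series: methoxy addition on the aryl ketone

This account rests on a few compounds, and the source may have more. Where it says the series, first, only, none or still open, it means among the compounds named here.

Measured compounds:
- compound 1 `COc1cc(-c2cc(/C=C/C(=O)c3ccc(N)cc3)[nH]n2)cc(OC)c1OC` in a functional assay on OVCAR-8 cells (Homo sapiens) for inhibition, read by sulforhodamine B assay, with a stated time of 48 h (on this read-out higher numbers stand for weaker inhibition of growth and lower numbers for stronger inhibition of growth), gives 2390 nM
- compound 2 `COc1ccc(C(=O)/C=C/c2cc(-c3cc(OC)c(OC)c(OC)c3)n[nH]2)cc1OC` in this assay gives 1320 nM
- compound 3 `COc1ccc(-c2cc(/C=C/C(=O)c3ccc(N)cc3)[nH]n2)cc1OC` in this assay gives 2950 nM

Compound 1 and compound 3 share a core; how the core of compound 2 differs from that of compound 3 is not broken down here. The step of a 1.2-fold lower number from compound 3 to compound 1 (0.09 log units; within the scatter) comes from the change methoxy in place of hydrogen on an aromatic carbon and is small. The step of a 1.8-fold lower number from compound 1 to compound 2 (0.26 log units; within the scatter) also stays within the usual scatter, so compound 2 cannot be called the most potent; only its gap to compound 3 lies beyond the scatter.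

Compound 4 `COc1cc(C(=O)/C=C/c2cc(-c3cc(OC)c(OC)c(OC)c3)n[nH]2)cc(OC)c1OC` is not yet measured. It differs from compound 2 by methoxy in place of hydrogen on an aromatic carbon. This is the same change as from compound 3 to compound 1, made on the same kind of place, with the same surroundings.

Because the earlier step of a 1.2-fold lower number from compound 3 to compound 1 (0.09 log units; within the scatter) was within the scatter, the expected step of a 1.2-fold lower number from compound 2 to compound 4 (0.08 log units; within the scatter) is likewise small, and the estimate for compound 4 rests on compound 2 at 1320 nM. Compound 4 is expected to give about 1100 nM, between 500 nM and 2500 nM.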

Compound 4, concentration for 50% growth inhibition: 1580 nM
Compound 4: the middle estimate sits 1.4-fold (0.16 log units) below what was measured; the measured number falls inside the stated range.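

In this assay the change of methoxy in place of hydrogen on an aromatic carbon gives a 1.2-fold higher number from compound 2 to compound 4 (0.08 log units; within the scatter) and so stays small on this core as well. With both steps inside the scatter, neither a shared direction nor any real effect of the added methoxy can be read from them, and two pairs of compounds give no rule for the whole series. What can be said is only that the change carried from one core to the other with no difference between the two steps beyond the scatter: the same change on two cores in this assay, a 1.2-fold lower number (0.09 log units; within the scatter) from compound 3 to compound 1 and a 1.2-fold higher number (0.08 log units; within the scatter) from compound 2 to compound 4, 1.5-fold (0.17 log units) apart, within the scatter of two such steps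

Open, on these data alone, is whether a different group on that aromatic carbon, such as a fluorine, an ethoxy or a carboxylic acid, would give a step beyond the scatter on either core. Also open is whether the small size of this step holds on cores other than the two shown here.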